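The compounds below may be only part of what the source reports. "The series", "measured", "known", "first", "only" and "open" are said of these compounds alone.

The compounds in this small series share one core and differ in the ring attached at a carbon with a double bond to nitrogen. Among the measured compounds shown here, in a functional assay on PC-3 cells (Homo sapiens) for antiproliferative activity, read by MTT assay, with a stated time of 72 h (a higher number here means a weaker inhibitor, a lower number a stronger inhibitor), compound 1 (`O=C(N/N=C/c1ccccc1)Nc1ccc(Oc2ccnc3[nH]ccc23)cc1`) gives 10200 nM and so far is the only one with a number. Compound 2 (`O=C(N/N=C/c1cccc(Cl)c1Cl)Nc1ccc(Oc2ccnc3[nH]ccc23)cc1`) comes back as "not active" (no number reported) in this assay with no number attached. Compound 3 (`COc1ccc(/C=N/NC(=O)Nc2ccc(Oc3ccnc4[nH]ccc34)cc2)cc1`) also comes back as "not active" (no number reported) in this assay. It therefore cannot be placed on the scale and shares this outcome with compound 2.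

Compound 4 (`O=C(N/N=C/c1ccc(O)cc1Br)Nc1ccc(Oc2ccnc3[nH]ccc23)cc1`) keeps the core but carries 2-bromo-4-hydroxyphenyl in place of 4-methoxyphenyl on a carbon with a double bond to nitrogen. For the measured compounds named here, none of the compounds tested so far carries this group, and with no number for compound 3, the size of the step cannot be calculated. A large gain in this assay is not expected, only a modest move towards stronger inhibition at best. Compound 4 is expected to stay weak, close to compound 1 at 10200 nM in the same test, or to give no number at all. The estimated value for compound 4 is 10000 nM with an expected range of 2500 nM to 40000 nM in this test.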

Compound 4, half-maximal inhibitory concentration: "not active" (no number reported)
For compound 4 the study gives words and no number, and the estimate cannot be compared.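

Compound 3 and compound 4 both come back from this assay as "not active" with no number, so no step can be read between them. Nothing shown here gives a reason for this outcome. Left open is whether 4-methoxyphenyl and 2-bromo-4-hydroxyphenyl differ in strength at all; compound 1 at 10200 nM remains the only compound with a number.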